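Sigma-1 binding: aryl substituent change on the shared core

The compounds below may be only part of what the source reports. "The series", "measured", "known", "first", "only" and "open" are said of these compounds alone.

Measured so far in an assay on membranes from Jurkat cells for displacement of a labelled ligand from Sigma non-opioid intracellular receptor 1 (Homo sapiens), read by scintillation counting, with a stated time of 2 h; a higher number here means a weaker inhibitor, a lower number a stronger inhibitor:
- compound 1 `Cn1nc(CN2CCCC2)nc1-c1ccc(C2(C(F)(F)F)CC2)cc1` gives 9.9 nM
- compound 2 `Cn1nc(CN2CCCC2)nc1-c1ccc2c(c1)CCCC2` gives 26 nM

Compound 1 stands lowest of the two numbers in this assay. Among the measured compounds shown here, compound 2 is its only neighbour, and the gap between the two values lies beyond the scatter, so compound 1 is the stronger binder of the pair on these data.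

Compound 3 `Cn1nc(CN2CCCC2)nc1-c1ccc(-c2ccccc2)cc1` has not been measured. It differs from compound 1 in one place: phenyl in place of 1-(trifluoromethyl)cyclopropyl on an aromatic carbon. For the measured compounds named here, no measured pair in the set shows exactly this exchange, so the size of the step has to be judged from the two values alone. Both measured compounds carry a bulky, non-polar group on the same side of the shared core and both bind in the low range, which suggests the site of change tolerates such groups. The step of a 1.5-fold higher number from compound 1 to compound 3 (0.18 log units; within the scatter) is therefore expected to be small, likely within the scatter or a modest weakening. For compound 3 in this assay the estimate is 15 nM, with a range from 5 nM to 50 nM.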

Compound 3, inhibition constant: 90 nM
Estimate against measurement, compound 3: 6.0-fold (0.78 log units) below; measured number outside the range, above it.
By their numbers in this assay, from the lowest: compound 1; then compound 2; then compound 3.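

In this assay, among the compounds shown here, phenyl in place of 1-(trifluoromethyl)cyclopropyl on an aromatic carbon gives a 9.1-fold higher number from compound 1 to compound 3 (0.96 log units; beyond the scatter), the first single-place step. This position therefore does not treat all large carbon-based groups alike, even though neither group has a hydrogen-bond donor, a hydrogen-bond acceptor or a net charge, and the step is not tied to any of these counts. Nothing measured here accounts for the size of the step.

From the compounds shown here alone, it remains open whether the stronger binding of compound 1 goes with the trifluoromethyl group, the cyclopropane ring or the two together, a question that plain cyclopropyl or tert-butyl at this position would address. Also open, going by these compounds, is how a pyridine ring or a methoxy-bearing phenyl would compare with the phenyl of compound 3.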